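Methoxy for chloro on the aryl ring of compound 1

The source may hold more compounds than are shown below. What is called first, only, known or untested is meant among the compounds shown, and "the series" means these compounds.

Compound 1 `Clc1ccc(-c2n[nH]cc2N2CCCNCC2)cc1` is one of three compounds sharing a core, examined for affinity in an assay on isolated protein for binding affinity to 5-hydroxytryptamine receptor 6 (Homo sapiens); a lower number here means a stronger inhibitor, a higher number a weaker inhibitor. In this assay compound 1 gives 1090 nM. Going by the values given here, compound 2 `Fc1cccc(-c2n[nH]cc2N2CCCNCC2)c1` gives 841 nM in this assay, a number that lies within the scatter of the one for compound 1, so the two cannot be ordered. Compound 3 `COc1ccccc1-c1n[nH]cc1N1CCCNCC1` carries its methoxy at a different position on the ring, and in this assay compound 3 gives only a limit, > 10000 nM. This is the limit of > 10000 nM in this assay, at which 1 of the 3 values shown sits, so compound 1 stands as the higher of the two actual numbers shown, with one further value known only as a limit.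

Compound 4 `COc1ccc(-c2n[nH]cc2N2CCCNCC2)cc1` has not yet been measured in this assay. It differs from compound 1 in one place: methoxy in place of chloro on an aromatic carbon. Among the compounds with values here, no measured pair follows this exchange, and the limit for compound 3 concerns another position, so it cannot be used to size this step.

Compound 4 is expected to be a weaker binder than compound 1, with an estimated step of a 2.3-fold higher number from compound 1 to compound 4 (0.36 log units; beyond the scatter) in this assay, an estimate of 2500 nM with a range from 800 nM to 8000 nM.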

Compound 4, inhibition constant: > 10000 nM
Compound 4: a limit, no number (the forecaster's own chance of this, stated with the estimate: 15%); middle value at least 4.0-fold (0.60 log units) away from the limit.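

In this assay, putting methoxy in place of chloro on this aromatic carbon, para to a large group, gives an at least 9.1-fold higher number from compound 1 to compound 4 (0.96 log units; beyond the scatter), the first step measured at this position, and one that lies beyond the scatter. The value of compound 4 is a limit and not a number, so the step has a lower bound but no upper end. Compound 3 had shown a limit only for methoxy at another position on the ring, whereas the limit now also holds at this position, and both methoxy compounds shown sit there: the limit of > 10000 nM in this assay, at which 2 of the 4 values shown sit.

On these data alone, what remains open is how far compound 4 actually lies from compound 1, and whether the oxygen or the added carbon of the methoxy group accounts for the step, which a hydroxyl or a methyl group at the same place could help to separate. As far as these compounds go, it is also open whether any other group here, such as an amine or a nitrile, would hold the affinity of compound 1 or improve on it.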